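Ethoxycarbonyl for cyano on a short-lived compound

A few compounds are considered here, and "the series" means these few. Any claim that something is new, unique, unknown or untested is made for them only; others in the source may bear on it.

Going by the values given here, in an ADME assay on a cell-free system (plasma, Homo sapiens) for metabolic stability (on this read-out higher numbers stand for a longer-lived compound and lower numbers for a shorter-lived compound), compound 1 (`CC(=O)OCOC(=O)N(C)/N=N/c1ccc(C#N)cc1`) gives 0.117 h and stands lowest of the three compounds measured so far. Compound 2 (`CCCCC(=O)OC[C@H]1O[C@@H](n2cnc3c(NC4CCCC4)ncnc32)[C@H](O)[C@@H]1O`) gives 0.3 h and compound 3 (`CCCCC(=O)OCOC(=O)Cc1c(C)n(C(=O)c2ccc(Cl)cc2)c2ccc(OC)cc12`) gives 2.07 h and both numbers lie beyond the scatter from that of compound 1. Among the compounds with values here, neither differs from compound 1 in one place only, so no measured step shows what a single change does here.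

Compound 4 (`CCOC(=O)c1ccc(/N=N/N(C)C(=O)OCOC(C)=O)cc1`) keeps the core of compound 1 but carries ethoxycarbonyl in place of cyano on an aromatic carbon. Within the data shown here, the data hold no measured example of this change. The expectation therefore rests on everything that compound 4 shares with compound 1 (0.117 h), and no shift beyond the scatter is expected in this assay here. The estimated step is a 1.3-fold higher number from compound 1 to compound 4 (0.11 log units; within the scatter) and stays within the scatter. Compound 4 is thus expected to show a half-life of about 0.15 h (0.06 h to 0.4 h).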

Compound 4, half-life: 0.2 h
Estimate against measurement, compound 4: 1.3-fold (0.12 log units) below, and the stated range covers the measured number.
By their numbers in this assay, from the lowest: compounds 1, 4 and 2 (each within the scatter of the next, the first and the last beyond it); then compound 3.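

Going by these compounds alone, the change of cyano to ethoxycarbonyl, on an aromatic carbon para to a large group, gives the first step that differs in one place only: in this assay it reads a 1.7-fold higher number from compound 1 to compound 4 (0.23 log units; within the scatter). On this read-out compound 1 and compound 4 cannot be told apart, so at this position the larger ethoxycarbonyl takes the place of cyano without a shift beyond the scatter. Nothing in the data explains this step or ties it to any feature of either group.

This single pair leaves open whether other groups at the same place, such as an amine, a carboxylic acid or an ester with a longer chain, would also stay within the scatter of compound 1. It also leaves open what a change elsewhere on the shared core would do in this assay.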